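Piperazine substituent swap on the isoxazole-linked aryl ether series

This account rests on a few compounds, and the source may have more. Where it says the series, first, only, none or still open, it means among the compounds named here.

Compound 1 `Cc1ccccc1COc1ccc(-c2cc(CN3CCN(Cc4ccc(C(F)(F)F)cc4)CC3)no2)cc1`: 1200 nM
Compound 2 `Fc1cccc(COc2ccc(-c3cc(CN4CCN(Cc5ccc(C(F)(F)F)cc5)CC4)no3)cc2)c1`: 1300 nM
Compound 3 `N#Cc1cccc(COc2ccc(-c3cc(CN4CCN(c5ccc(C(F)(F)F)cc5)CC4)no3)cc2)c1`: 2200 nM

In a functional assay on Huh-7 cells (Homo sapiens) for antiproliferative activity, read by sulforhodamine B assay, with a stated time of 72 h (on this read-out lower numbers stand for stronger inhibition and higher numbers for weaker inhibition), compound 3 gives 2200 nM, a number that sits within the scatter of both compound 1 and compound 2. For the measured compounds named here, the only single-place step measured, a 1.1-fold higher number from compound 1 to compound 2 (0.03 log units; within the scatter), changes the benzyl ether end, not the piperazine nitrogen, and so does not bear on the present change. Compound 4 `N#Cc1cccc(COc2ccc(-c3cc(CN4CCN(CC5CC5)CC4)no3)cc2)c1` differs from compound 3 by cyclopropylmethyl in place of 4-(trifluoromethyl)phenyl on an amine nitrogen in a ring. Going by the values given here, no measured step of this kind exists, so the expectation rests on the absence of precedent rather than on data. The step from compound 3 to compound 4 is estimated as a 1.4-fold higher number from compound 3 to compound 4 (0.13 log units; within the scatter). Compound 4 is therefore estimated at 3000 nM, with a range from 1000 nM to 9000 nM.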

Compound 4, half-maximal inhibitory concentration: 2900 nM
Compound 4: middle estimate off by 1.0-fold (0.01 log units), on the high side, within the range that was stated.
By their numbers in this assay, from the lowest: compounds 1, 2, 3 and 4 (each within the scatter of the next, the first and the last beyond it).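

In this assay, cyclopropylmethyl in place of 4-(trifluoromethyl)phenyl on the amine nitrogen in a ring gives a 1.3-fold higher number from compound 3 to compound 4 (0.12 log units; within the scatter), the first single-place step read at this position. The group on this nitrogen can therefore go from 10 heavy atoms to 4 heavy atoms, and lose its aromatic ring and its fluorine, without a step beyond the scatter. No measurement at hand accounts for this result. Going by these compounds, whether a carboxylic acid, a primary amine or a longer chain on this nitrogen would give a step beyond the scatter remains open.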